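Three Limits Ahead of Compound 4

A few compounds are considered here, and "the series" means these few. Any claim that something is new, unique, unknown or untested is made for them only; others in the source may bear on it.

Compound 1 (`C=C[C@@](C)(/C=C/c1ccc(Nc2ccc(OC)cc2)cc1)CCC=C(C)C`) carries a 4-methoxyphenyl group on a nitrogen of the shared core. In a functional assay on NALM-6 cells (Homo sapiens) for cytotoxicity, with a stated time of 72 h (on this read-out higher numbers stand for an effect only at larger amounts of compound and lower numbers for an effect already at smaller amounts), compound 1 gives > 43400 nM as a limit of the assay and not a number. In this assay compound 2 (`C=C[C@@](C)(/C=C/c1ccc(Nc2ccc(F)cc2)cc1)CCC=C(C)C`) gives > 43400 nM as a limit as well. In this assay compound 3 (`C=C[C@@](C)(/C=C/c1ccc(Nc2cc(F)c(F)c(F)c2)cc1)CCC=C(C)C`) also gives only a limit (> 43400 nM). Compound 3 therefore has no number of its own and stands with the others at the limit of > 43400 nM in this assay, at which 3 of the 3 values shown sit, and no order can be read among the three.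

Compound 4 (`C=C[C@@](C)(/C=C/c1ccc(Nc2ccc(Cl)cc2)cc1)CCC=C(C)C`) has 4-chlorophenyl in place of 3,4,5-trifluorophenyl on a nitrogen on an aromatic ring. Within the data shown here, three measured steps bear on this change, as each alters the same group on that nitrogen. They are a step that the two limits leave unreadable from compound 1 to compound 2 and a step that the two limits leave unreadable from compound 1 to compound 3 and a step that the two limits leave unreadable from compound 2 to compound 3 and none has a size that can be read. They offer no ground for a direction, and all three end at the same limit. No step beyond the scatter is therefore expected, and the estimated step reads a step that the limit leaves unreadable from compound 3 to compound 4 with a further limit the likeliest report. In this assay compound 4 is expected at 50000 nM (estimated range 25000 nM to 100000 nM).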

Compound 4, half-maximal effective concentration: > 43400 nM
Compound 4: no number, only a limit; the forecaster's own chance of this, stated with the estimate: 85%; the middle value is on the limit's open side.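

In this assay compound 4 gives > 43400 nM, a limit of the assay and not a number. The steps to compound 4 from compound 1, compound 2 and compound 3 therefore cannot be read: the limit of > 43400 nM in this assay, at which 4 of the 4 values shown sit.

The compounds shown leave open whether any of these groups on the nitrogen alters the read-out, and how the four compounds would rank.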